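Anilino for benzylamino on a nitropyrimidine: an untested swap

The source may report more compounds than this note shows. Statements on the series, on what has been measured and on what is new or still open speak of the compounds shown alone.

Measured compounds and their numbers in a functional assay on MDA-MB-231 cells (Homo sapiens) for antiproliferative activity, read by MTT assay, with a stated time of 48 h; a higher number here means a weaker inhibitor, a lower number a stronger inhibitor:
compound 1 `CCOC(=O)CN(Cc1ccccc1)c1nc(NCc2cccc(OC)c2)ncc1[N+](=O)[O-]`, compound 1 gives 80700 nM
compound 2 `COC(=O)CN(C)c1nc(NCc2ccccc2)ncc1[N+](=O)[O-]`, compound 2 gives 61100 nM
compound 3 `CCOC(=O)CNc1nc(NCc2ccccc2)ncc1[N+](=O)[O-]`, compound 3 gives 22300 nM

Among these three, compound 1 holds the highest number. Its nearest neighbour is compound 2, whose number lies within the scatter of that of compound 1, so no order between those two can be claimed. Compound 3 stands furthest away, with a number beyond the scatter below that of compound 1. Among the compounds with values here, the one step measured at a single position is a 2.7-fold lower number from compound 2 to compound 3 (0.44 log units; beyond the scatter); it concerns the amino substituent carrying the ester chain, not the other side of the shared core.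

Compound 4 `CCOC(=O)CN(Cc1ccccc1)c1nc(Nc2cccc(OC)c2)ncc1[N+](=O)[O-]` differs from compound 1 in one place: 3-methoxyphenyl in place of 3-methoxybenzyl on a nitrogen on an aromatic ring. Within the data shown here, none of the measured steps touches this nitrogen, so the data give no direct guide to the size or direction of the change. With nothing to lean on beyond the position of compound 1, the number for compound 4 is expected to stay close to that of compound 1, with a 1.2-fold lower number from compound 1 to compound 4 (0.06 log units; within the scatter) judged as no step beyond the scatter. Compound 4 is therefore estimated at 70000 nM, within a range from 25000 nM to 200000 nM.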

Compound 4, half-maximal inhibitory concentration: 47200 nM
Estimate against measurement, compound 4: 1.5-fold (0.17 log units) above; low and high end bracket the measured number.
By their numbers in this assay, from the lowest: compound 3; then compounds 4, 2 and 1 (each within the scatter of the next).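

In this assay, within the data shown here, the first measured step at this nitrogen is a 1.7-fold lower number from compound 1 to compound 4 (0.23 log units; within the scatter), so no order can be claimed between the two compounds. Exchanging 3-methoxybenzyl for 3-methoxyphenyl takes the substituent from 9 heavy atoms to 8 and keeps its one aromatic ring and its one hydrogen-bond acceptor, and at this resolution the read-out does not separate the two forms. Among these compounds, the earlier step, a 2.7-fold lower number from compound 2 to compound 3 (0.44 log units; beyond the scatter), lay beyond the scatter but concerned the amino substituent carrying the ester chain, whereas this result gives the first reading on the other side of the shared core, and no supporting data are available to account for it.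

The compounds shown leave open whether a 2-(3-methoxyphenyl)ethyl group on this nitrogen, or a phenyl ring carrying a fluorine or an amine in place of the methoxy group, would give a step beyond the scatter. They also leave open whether the exchange of (3-methoxybenzyl)amino for (3-methoxyphenyl)amino would read the same alongside a carboxylic acid in place of the ethyl ester.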